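The compounds below may be only part of what the source reports. "The series", "measured", "known", "first", "only" and "open" are said of these compounds alone.

Compound 1 `O=C1Nc2ccccc2/C1=N/NC(=S)N1CCN(c2ccccc2)CC1` gives 18600 nM in a functional assay on A549 cells (Homo sapiens) for inhibition, read by MTT assay, with a stated time of 72 h; on this read-out lower numbers stand for stronger inhibition and higher numbers for weaker inhibition. Compound 2 `O=C1Nc2ccc(F)cc2/C1=N/NC(=S)N1CCN(c2ccccc2)CC1` gives 20700 nM in this assay. Compound 3 `O=C1Nc2ccc(Cl)cc2/C1=N/NC(=S)N1CCN(c2ccccc2F)CC1` gives 10500 nM in this assay.

Compound 2 differs from compound 1 by fluoro in place of hydrogen on an aromatic carbon, and that change made a 1.1-fold higher number from compound 1 to compound 2 (0.05 log units; within the scatter). The difference between the core of compound 1 and the core of compound 3 is not broken down here. Compound 4 `O=C1Nc2ccc(Cl)cc2/C1=N/NC(=S)N1CCN(c2ccc(F)cc2F)CC1` differs from compound 3 by fluoro in place of hydrogen on an aromatic carbon. This is the same kind of change as from compound 1 to compound 2, but not the same: there the fluoro enters on a ring that is part of a fused or bridged system of two rings, meta and para to a fused ring, whereas here it enters on a ring of carbon only, meta to a fluoro group and para to a large group. Because the earlier step of a 1.1-fold higher number from compound 1 to compound 2 (0.05 log units; within the scatter) stayed within the scatter, compound 4 is expected to show a similarly small step a 1.0-fold higher number from compound 3 to compound 4 (0.02 log units; within the scatter). Compound 4 is therefore estimated at 11000 nM in this assay.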

Compound 4, half-maximal inhibitory concentration: 11400 nM
For compound 4 the middle estimate is 1.0-fold (0.02 log units) below the measured one; measured number inside the range.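

In this assay, fluoro in place of hydrogen on an aromatic carbon gave a 1.1-fold higher number from compound 3 to compound 4 (0.04 log units; within the scatter), and the same change on the two cores agrees: the same change on two cores in this assay, a 1.1-fold higher number (0.05 log units; within the scatter) from compound 1 to compound 2 and a 1.1-fold higher number (0.04 log units; within the scatter) from compound 3 to compound 4, 1.0-fold (0.01 log units) apart, within the scatter of two such steps

On these two pairs, the change carried from one core to the other with no step beyond the scatter. Both steps are small, however, so this agreement does not show that the change has any effect on the read-out, nor does it show how it would behave on cores other than these two.

The compounds shown leave open how a group other than fluoro, such as methoxy or trifluoromethyl, would read on the ring of carbon only. From the compounds shown here alone, an amine or a carboxylic acid at that place also remains open.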